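Side-chain carbonyl removal: compound 2 to compound 3

This account rests on a few compounds, and the source may have more. Where it says the series, first, only, none or still open, it means among the compounds named here.

Compound 1 `CN1CCN(C23CCN(CCCN4CCCCC4)C(C(c4ccccc4)C2)C(c2ccccc2)C3)CC1` gives 28900 nM here
Compound 2 `CN1CCN(C23CC(NCCC(=O)N4CCCC4)C(C(c4ccccc4)C2)C(c2ccccc2)C3)CC1` gives 21500 nM here

In an ADME assay on L6 cells (Rattus norvegicus) for cytotoxicity, read by fluorescence, with a stated time of 72 h (on this read-out lower numbers stand for stronger inhibition and higher numbers for weaker inhibition), compound 2 stands at 21500 nM and lies within the usual scatter of compound 1, so the two measured values cannot be separated. Within the data shown here, no pair of measured compounds differs in one place only, which leaves the series without a measured step to draw on.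

Compound 3 `CN1CCN(C23CC(NCCCN4CCCC4)C(C(c4ccccc4)C2)C(c2ccccc2)C3)CC1` has not yet been measured in this assay and is the next point of interest. Its structure follows from compound 2 by one change: (pyrrolidin-1-yl)methyl in place of (pyrrolidin-1-yl)carbonyl on a saturated chain carbon, two bonds along the chain from an amine nitrogen, with (pyrrolidin-1-yl)methyl in place of (pyrrolidin-1-yl)carbonyl on a saturated chain carbon, two bonds along the chain from an amine nitrogen. The side chain thus reads (3-(pyrrolidin-1-yl)propyl)amino instead of (2-((pyrrolidin-1-yl)carbonyl)ethyl)amino.

Among the measured compounds shown here, with only two close values available, no step beyond the scatter is expected, and any drift towards a lower number would be slight. The expected change is a 1.2-fold lower number from compound 2 to compound 3 (0.08 log units; within the scatter), an estimate that carries wide uncertainty. For compound 3 the estimated value is 18000 nM, with an expected range from 6000 nM to 50000 nM on this basis.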

Compound 3, half-maximal inhibitory concentration: 22600 nM
Beside the measured number, compound 3's estimate is 1.3-fold (0.10 log units) below it; low and high end bracket the measured number.
By their numbers in this assay, from the lowest: compounds 2, 3 and 1 (each within the scatter of the next).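

In this assay, the series now has its first measured step: (pyrrolidin-1-yl)methyl in place of (pyrrolidin-1-yl)carbonyl on a saturated chain carbon, two bonds along the chain from an amine nitrogen, gives a 1.1-fold higher number from compound 2 to compound 3 (0.02 log units; within the scatter) and so does not separate the two compounds. At this position, then, exchanging the carbonyl for a methylene, which removes the oxygen and the double bond outside aromatic rings while keeping the pyrrolidine ring and the chain length, produces no readable change in cytotoxicity on this read-out. No accompanying measurement bears on why the two compounds cannot be told apart, so the result stands as an observation without an explanation.

Still open, on these data alone, is whether a carboxylic acid or a primary amine at the end of this chain, or a longer chain carrying the pyrrolidine ring, would give a step beyond the scatter. Compound 1 differs from compound 3 in more than one place, so the part played by the way its side chain is attached to the shared core remains unresolved.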